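Hydroxy to methoxy: the next step in the series

A few compounds are considered here, and "the series" means these few. Any claim that something is new, unique, unknown or untested is made for them only; others in the source may bear on it.

In an ADME assay on RAW264.7 cells (Mus musculus) for cytotoxicity, read by MTT assay, with a stated time of 24 h (a higher number here means that more compound is tolerated, a lower number that less compound is tolerated), compound 1 (`CC/C=C\C[C@H]1C(=O)C=C[C@H]1CC(=O)OCCCCC`) gives 37 uM and compound 2 (`CC/C=C\C[C@H]1C(=O)C=C[C@H]1CC(=O)OCCOCCO`) gives 166 uM as the higher of the two numbers. Compound 3 (`CC/C=C\C[C@H]1C(=O)C=C[C@H]1CC(=O)OCCOCCOC`) has methyl in place of hydrogen on an oxygen on a saturated carbon, hydroxy to methoxy (methyl in place of hydrogen on an oxygen on a saturated carbon). Within the data shown here, only one measured step bears on this, a modest one beyond the scatter (a 4.5-fold higher number from compound 1 to compound 2 (0.65 log units; beyond the scatter)), and it is a different change, so it offers weak guidance. A small fall within the scatter is expected in this assay (a 1.4-fold lower number from compound 2 to compound 3 (0.14 log units; within the scatter)). The estimate for compound 3 is 120 uM with 60 uM to 210 uM as the expected range.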

Compound 3, half-maximal toxic concentration: 161 uM
Estimate against measurement, compound 3: 1.3-fold (0.13 log units) below; the measured number falls inside the stated range.
By their numbers in this assay, from the lowest: compound 1; then compounds 3 and 2 (each within the scatter of the next).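

In this assay, compound 2 and compound 3 cannot be told apart (a 1.0-fold lower number from compound 2 to compound 3 (0.01 log units; within the scatter)), so methyl in place of hydrogen on this oxygen leaves no readable difference. With 2-methoxyethoxy in place of propyl, the step stays beyond the scatter (a 4.4-fold higher number from compound 1 to compound 3 (0.64 log units; beyond the scatter)), so the higher number does not depend on a free terminal hydroxy. Nothing available explains the difference from compound 1.

Open, on these data alone, is whether a longer chain of the same kind would tolerate still more compound. Also open, as far as these compounds go, is how an amine or a carboxylic acid at the chain end would read.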